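Series notes: chloro on the benzoyl ring

A few compounds are considered here, and "the series" means these few. Any claim that something is new, unique, unknown or untested is made for them only; others in the source may bear on it.

Measured so far:
compound 1 `O=C(Nc1ccccc1O)C1CCc2ccccc2N1C(=O)c1ccc(Cl)cc1` gives 19600 nM
compound 2 `O=C(Nc1ccccc1O)C1CCc2ccccc2N1C(=O)c1ccccc1` gives 4260 nM
compound 3 `O=C(Nc1cc(C(F)(F)F)cc(C(F)(F)F)c1)C1CCc2ccccc2N1C(=O)c1ccccc1` gives 2920 nM

All three compounds were read in a functional assay on ACHN cells (Homo sapiens) for cytotoxicity, read by sulforhodamine B assay, with a stated time of 72 h; a higher number here means a weaker inhibitor of growth, a lower number a stronger inhibitor of growth. Compound 2 differs from compound 1 by one change, (chloro in place of hydrogen on an aromatic carbon), and that change made a step of a 4.6-fold higher number from compound 2 to compound 1 (0.66 log units; beyond the scatter). Compound 3 carries a different core from compound 2; the difference between the two cores is not broken down here. Compound 3 has the lowest number of the three, but its gap to compound 2 is within the scatter, so no order between those two is claimed; only its gap to compound 1 lies beyond the scatter.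

Compound 4 `O=C(Nc1cc(C(F)(F)F)cc(C(F)(F)F)c1)C1CCc2ccccc2N1C(=O)c1cccc(Cl)c1` has not yet been measured. It differs from compound 3 by chloro in place of hydrogen on an aromatic carbon. For the measured compounds named here, this is the same kind of change as the one from compound 2 to compound 1, not the same: in compound 1 the chloro sits para to a large group, in compound 4 it sits meta to a large group, and the cores differ as noted.

For compound 4 in this assay a step of a 2.4-fold higher number from compound 3 to compound 4 (0.38 log units; beyond the scatter) is expected, a weaker growth inhibitor than compound 3, resting on the step of a 4.6-fold higher number from compound 2 to compound 1 (0.66 log units; beyond the scatter) seen with the related change on the other core. That step lies beyond the scatter, and the place of the chloro differs. A somewhat smaller shift in the same direction is estimated. Compound 4 is expected to give about 7000 nM, with a range from 2500 nM to 20000 nM.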

Compound 4, concentration for 50% growth inhibition: 813 nM
Compound 4: the middle estimate sits 8.6-fold (0.94 log units) above what was measured; measured number below the stated range.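

In this assay, chloro in place of hydrogen on an aromatic carbon gave a 3.6-fold lower number from compound 3 to compound 4 (0.56 log units; beyond the scatter), and set beside the earlier pair, the step runs the opposite way: the same change on two cores in this assay, a 4.6-fold higher number (0.66 log units; beyond the scatter) from compound 2 to compound 1 and a 3.6-fold lower number (0.56 log units; beyond the scatter) from compound 3 to compound 4, 17-fold (1.22 log units) apart, beyond the scatter of two such steps

The change therefore cannot be carried as a fixed shift, or even as a fixed direction, from the core of compound 2 to the core of compound 3; on these two pairs, a chloro on the benzoyl ring made for a weaker growth inhibitor in one case and a stronger one in the other. This does not show what sets the direction, as the two pairs differ both in the core and in the place of the chloro, which is meta to a large group in compound 4 and elsewhere in compound 1, and the data do not separate these two differences.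

Open, as far as these compounds go, is how the 3-chlorophenyl group behaves on the core of compound 2 and how a chloro placed as in compound 1 behaves on the core of compound 3, the two comparisons that would pull core and place apart. Also open, from the compounds shown here alone, is whether another group at the place of the chloro in compound 4, such as a methoxy or an amine, would follow the chloro or not.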